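The source may report more compounds than this note shows. Statements on the series, on what has been measured and on what is new or still open speak of the compounds shown alone.

Working notes on the series.

Compound 1 `CCCCCOc1cc(C(C)(C)C)ccc1C/N=C(\S)NCc1ccc(NS(C)(=O)=O)cc1` gives the lowest number of the three compounds measured in a functional assay for inhibition of Vanilloid receptor (Rattus norvegicus) (on this read-out lower numbers stand for stronger inhibition and higher numbers for weaker inhibition), at 70 nM. Compound 2 `CCCCCCOc1cc(C(C)(C)C)ccc1C/N=C(\S)NCc1ccc(NS(C)(=O)=O)cc1` gives 150 nM in this assay, and compound 3 `CC(C)Oc1cc(C(C)(C)C)ccc1C/N=C(\S)NCc1ccc(NS(C)(=O)=O)cc1` gives 350 nM. The steps from compound 1 run in both directions of chain length: a 2.1-fold higher number from compound 1 to compound 2 (0.33 log units; beyond the scatter), and a 5.0-fold higher number from compound 1 to compound 3 (0.70 log units; beyond the scatter). Between the two longer chains, a 2.3-fold higher number from compound 2 to compound 3 (0.37 log units; beyond the scatter).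

Compound 4 `COCCOc1cc(C(C)(C)C)ccc1C/N=C(\S)NCc1ccc(NS(C)(=O)=O)cc1` has not yet been measured in this assay. Relative to compound 1 the change is methoxy in place of propyl on a saturated chain carbon, two bonds along the chain from an oxygen on an aromatic ring. The chain on the aromatic oxygen is thus cut back from pentyloxy to 2-methoxyethoxy, with an ether oxygen now in the chain. The step that bears most directly on this is the shortening from compound 1 to compound 3, which gave a clearly higher number; the step from compound 1 to compound 2 shows that the pentyloxy chain is the best of those measured. A step towards a higher number is therefore expected, of about a 4.3-fold higher number from compound 1 to compound 4 (0.63 log units; beyond the scatter). For compound 4 in this assay the estimate is 300 nM, with a range from 100 nM to 1000 nM.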

Compound 4, half-maximal inhibitory concentration: 60 nM
For compound 4 the middle estimate is 5.0-fold (0.70 log units) above the measured one; measured number below the stated range.
By their numbers in this assay, from the lowest: compounds 4 and 1 (each within the scatter of the next); then compound 2; then compound 3.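

At this position, on a saturated chain carbon two bonds along the chain from the oxygen on the aromatic ring, methoxy in place of propyl leaves this assay unchanged within the scatter, with a 1.2-fold lower number from compound 1 to compound 4 (0.07 log units; within the scatter). The 2-methoxyethoxy chain, with an ether oxygen in it, therefore keeps the standing of pentyloxy relative to the other two chains, giving a 2.5-fold lower number from compound 2 to compound 4 (0.40 log units; beyond the scatter) and a 5.8-fold lower number from compound 3 to compound 4 (0.77 log units; beyond the scatter). No supporting data are available to explain this result.

Open, going by these compounds, is how a butoxy chain, an all-carbon counterpart, would compare with 2-methoxyethoxy, and so what the ether oxygen itself contributes. Also open, on these data alone, is whether a terminal hydroxyl, an amine or a longer ether such as 2-ethoxyethoxy would hold the number at this level.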